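The compounds below may be only part of what the source reports. "The series", "measured", "known", "first", "only" and "open" are said of these compounds alone.

Measured compounds:
compound 1 `CCOC(=O)c1c(N)sc(/N=C/c2ccc(N(C)C)cc2)c1C(=O)OCC`: 5700 nM
compound 2 `CCOC(=O)c1c(N)sc(/N=C/c2ccncc2)c1C(=O)OCC`: 92200 nM
compound 3 `CCOC(=O)c1c(N)sc(/N=C/c2ccco2)c1C(=O)OCC`: 62200 nM

In a functional assay on MCF7 cells (Homo sapiens) for inhibition, read by MTT assay, with a stated time of 48 h (on this read-out higher numbers stand for weaker inhibition and lower numbers for stronger inhibition), compound 3 stands second highest of the three numbers; compound 2 is nearest, a 1.5-fold lower number from compound 2 to compound 3 (0.17 log units; within the scatter), and compound 1 lies furthest, an 11-fold higher number from compound 1 to compound 3 (1.04 log units; beyond the scatter). Compound 4 `CCOC(=O)c1c(N)sc(/N=C/c2ccc([N+](=O)[O-])cc2)c1C(=O)OCC` carries the change (4-nitrophenyl in place of furan-2-yl on a carbon with a double bond to nitrogen). For the measured compounds named here, no measured step installs a 4-nitrophenyl group. Going by the values given here, the one step bearing on a swap of a five-membered aromatic ring with 1 hetero atom for a six-membered aromatic ring of carbon only is an 11-fold higher number from compound 1 to compound 3 (1.04 log units; beyond the scatter), but there the entering group was 4-(dimethylamino)phenyl, so it is a loose guide; a 1.5-fold lower number from compound 2 to compound 3 (0.17 log units; within the scatter) shows two such five-membered rings giving similar numbers. A moderate step down is expected, a 3.1-fold lower number from compound 3 to compound 4 (0.49 log units; beyond the scatter), with wide uncertainty. Compound 4 is estimated at 20000 nM, range 4000 nM to 90000 nM.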

Compound 4, half-maximal inhibitory concentration: 1300 nM
Compound 4: middle estimate off by 15-fold (1.19 log units), on the high side; measured number below the stated range.
By their numbers in this assay, from the lowest: compound 4; then compound 1; then compounds 3 and 2 (each within the scatter of the next).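

In this assay, a 4-nitrophenyl group on this carbon with a double bond to nitrogen gives far lower numbers than either furan-2-yl (a 48-fold lower number from compound 3 to compound 4 (1.68 log units; beyond the scatter)) or pyridin-4-yl (a 71-fold lower number from compound 2 to compound 4 (1.85 log units; beyond the scatter)). Low numbers here therefore do not depend on the dimethylamino group, and nitro in its place on the aromatic carbon lowers the number further (a 4.4-fold lower number from compound 1 to compound 4 (0.64 log units; beyond the scatter)). Still open, from the compounds shown here alone, is whether an unsubstituted phenyl or a 4-chlorophenyl group would give numbers like those of compound 1 and compound 4. No supporting data explain why these two substituted phenyl compounds give the lowest numbers.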